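The compounds below may be only part of what the source reports. "The series", "measured", "known", "first", "only" and "open" are said of these compounds alone.

Measured so far in a physicochemical assay for solubility; a higher number here means a more soluble compound, a lower number a less soluble compound:
Compound 1 `NS(=O)(=O)C1CCN(c2ncc(C(=O)Nc3nc(-c4cccc(C(F)(F)F)c4F)cs3)cc2Cl)CC1` gives < 10 ug/mL, a limit of the assay rather than a number.
Compound 2 `C[C@@H](Nc1ncc(C(=O)Nc2nc(-c3cccc(C(F)(F)F)c3F)cs2)cc1Cl)C(=O)O` gives < 10 ug/mL, likewise a limit.

Within the data shown here, compound 2 stands at the limit of this assay, and the one other value shown is a limit too, so its position on the numbers is known only as a bound. The step that the two limits leave unreadable from compound 1 to compound 2 is therefore not readable in size or direction. the limit of < 10 ug/mL in this assay, at which 2 of the 2 values shown sit, is all that the two measurements offer.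

Compound 3 `O=C(Nc1nc(-c2cccc(C(F)(F)F)c2F)cs1)c1cnc(N2CCNC(C(=O)O)C2)c(Cl)c1` differs from compound 2 in one place: 3-carboxypiperazin-1-yl in place of (1-carboxyethyl)amino on an aromatic carbon. Among the measured compounds shown here, the only measured step, from compound 1 to compound 2, bears on it merely by showing that two different groups on the same aromatic carbon both leave the compound at the limit; how large a change a third group there makes cannot be read from it. No step beyond the scatter of this assay is therefore expected, and the most likely outcome for compound 3 is again a limit. Compound 3 is estimated at 8 ug/mL, within 2 ug/mL to 40 ug/mL, which means an expected step that the limit leaves unreadable from compound 2 to compound 3.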

Compound 3, solubility: < 10 ug/mL
Compound 3: no number, only a limit (the forecaster's own chance of this, stated with the estimate: 60%); the middle value lies beyond the limit too.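

Among these compounds, compound 3 also gives only a limit in this assay, so no step among compound 1, compound 2 and compound 3 can be read, either in size or in direction: the limit of < 10 ug/mL in this assay, at which 3 of the 3 values shown sit. The compounds shown leave open how soluble each of the three actually is, and whether changing the group on that aromatic carbon makes any difference.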